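Compound 2 to compound 3: a tert-butyl swap

The compounds below may be only part of what the source reports. "The series", "measured", "known", "first", "only" and "open" are said of these compounds alone.

In a physicochemical assay for solubility, at pH 7 (a higher number here means a more soluble compound, a lower number a less soluble compound), compound 2 (`CC1(C)c2[nH]nc(NC(=O)c3ccc(F)cc3)c2CN1C(=O)C1CCN(C2CC2)CC1`) reads > 225000 nM as a limit of the assay, not a number. Compound 1 (`CC(C)(C)C(=O)N1Cc2c(NC(=O)C3CCNCC3)n[nH]c2C1(C)C`) reads > 225000 nM in this assay and is also a limit. Within the data shown here, the record so far is the limit of > 225000 nM in this assay, at which 2 of the 2 values shown sit, and offers no step between measured compounds.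

Starting from compound 2, compound 3 (`CC(C)(C)C(=O)N1Cc2c(NC(=O)c3ccc(F)cc3)n[nH]c2C1(C)C`) carries tert-butyl in place of 1-cyclopropylpiperidin-4-yl on a carbonyl carbon. Compound 1 already carries tert-butyl on a carbonyl carbon. Compound 3 is the only one of the three without a six-membered non-aromatic ring with 1 hetero atom.

The expectation of a lower reading in this assay rests on that difference and on compound 2 at > 225000 nM as a limit with the ring present. No measured step sizes this move, so the estimate is loose. The expected step is an at least 3.7-fold lower number from compound 2 to compound 3 (0.57 log units; beyond the scatter) as a downward move beyond the scatter. For compound 3 the estimate is 60000 nM with an expected range of 12000 nM to 225000 nM in this working view.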

Compound 3, solubility: 235000 nM
Estimate against measurement, compound 3: 3.9-fold (0.59 log units) below; measured number above the stated range.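

Neither the change from compound 2 to compound 3 nor the change from compound 1 to compound 3 can be sized in this assay, because compound 1 and compound 2 both stand at a limit of the assay: the limit of > 225000 nM in this assay, at which 2 of the 3 values shown sit.

The compounds shown leave open whether tert-butyl in place of 1-cyclopropylpiperidin-4-yl on a carbonyl carbon changes the reading at all, and in which direction.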